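Benzyl-triazole chromone series: cytotoxicity, compound 4 expected

The compounds below may be only part of what the source reports. "The series", "measured", "known", "first", "only" and "open" are said of these compounds alone.

Compound 1 `O=c1ccoc2cc(OCc3cn(Cc4ccccc4)nn3)ccc12`: > 100000 nM
Compound 2 `O=c1ccoc2cc(OCc3cn(Cc4ccc(Cl)cc4Cl)nn3)ccc12`: 5260 nM
Compound 3 `O=c1ccoc2cc(OCc3cn(Cc4ccc(Br)cc4)nn3)ccc12`: > 100000 nM

All three share the core of compound 1 and differ only in the group on a saturated chain carbon bound to an aromatic nitrogen. In a functional assay on A549 cells (Homo sapiens) for cytotoxicity, read by MTT assay, with a stated time of 48 h (a lower number here means a stronger inhibitor, a higher number a weaker inhibitor), compound 1 gives only a limit, > 100000 nM. Compound 3 likewise gives only a limit, > 100000 nM. For the measured compounds named here, compound 2 gives the one number in this assay, 5260 nM, and stands alone, since the other two values sit at the limit of > 100000 nM in this assay, at which 2 of the 3 values shown sit. The measured steps are an at least 19-fold lower number from compound 1 to compound 2 (1.27 log units; beyond the scatter) and an at least 19-fold higher number from compound 2 to compound 3 (1.27 log units; beyond the scatter); the remaining pair gives a step that the two limits leave unreadable from compound 1 to compound 3.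

Compound 4 `N#Cc1ccc(Cn2cc(COc3ccc4c(=O)ccoc4c3)nn2)cc1` is unmeasured. The change from compound 2 is 4-cyanophenyl in place of 2,4-dichlorophenyl on a saturated chain carbon bound to an aromatic nitrogen. Both large steps bear on it: each time the 2,4-dichlorophenyl is absent the number rises to a limit, and the change to compound 4 also removes it. A large rise in this assay is therefore expected, quite possibly to a limit. Compound 4 is expected near 60000 nM, within 10000 nM to 200000 nM. The expected step is an 11-fold higher number from compound 2 to compound 4 (1.06 log units; beyond the scatter).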

Compound 4, half-maximal inhibitory concentration: > 100000 nM
Compound 4 was reported as a limit; the forecaster's own chance of this, stated with the estimate: 55%; middle value at least 1.6-fold (0.22 log units) away from the limit.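

In this assay compound 4 gives only a limit, > 100000 nM. For the compounds shown here, the change to 4-cyanophenyl brings an at least 19-fold higher number from compound 2 to compound 4 (1.27 log units; beyond the scatter), so a ring carrying a nitrile, like the 4-bromophenyl of compound 3, does not keep the readable value of compound 2, and 2,4-dichlorophenyl remains the only group on this saturated chain carbon bound to an aromatic nitrogen with a number. The steps from compound 1 and from compound 3 to compound 4 cannot be read, and the series now stands thus: the limit of > 100000 nM in this assay, at which 3 of the 4 values shown sit.

Open, as far as these compounds go, is whether a single chlorine, as in 4-chlorophenyl, is enough to give a readable value at this position. Also open, from the compounds shown here alone, is whether 2,4-dibromophenyl would give a value close to that of compound 2.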